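The compounds below may be only part of what the source reports. "The series", "measured", "known", "first", "only" and "open" are said of these compounds alone.

Working notes on the shared core of compound 1 `COC(=O)/C=C/c1cccc(N(Cc2ccc(-c3cccc(Cl)c3)cc2)C(=O)C2CCCCC2)c1`. In an assay on isolated protein with Bile acid receptor (Homo sapiens) as the target (on this read-out higher numbers stand for an effect only at larger amounts of compound and lower numbers for an effect already at smaller amounts), compound 1 gives 94 nM, and compound 2 `COC(=O)/C=C/c1cccc(N(Cc2ccc(-c3c(OC)cccc3OC)cc2)C(=O)C2CCCCC2)c1` gives 77 nM. Compound 3 `COC(=O)/C=C/c1cccc(N(Cc2ccc(C(C)(C)C)cc2)C(=O)C2CCCCC2)c1` gives > 1000 nM in this assay, which is a limit of the assay and not a number. Compound 3 therefore stands at the limit of > 1000 nM in this assay, at which 1 of the 3 values shown sits, the weakest of the three measured compounds. The change to compound 4 `COC(=O)/C=C/c1cccc(N(Cc2ccc(/C=C/c3ccc(OC)cc3)cc2)C(=O)C2CCCCC2)c1` is 2-(4-methoxyphenyl)ethenyl in place of tert-butyl on an aromatic carbon. The measured steps that bear on it are an at least 10-fold higher number from compound 1 to compound 3 (1.02 log units; beyond the scatter) and an at least 12-fold higher number from compound 2 to compound 3 (1.11 log units; beyond the scatter), both large; each exchanged an aromatic substituent for tert-butyl and lost potency. Reinstating an aromatic-bearing group in compound 4 is expected to reverse that, with an estimated step of an at least 8.3-fold lower number from compound 3 to compound 4 (0.92 log units; beyond the scatter). Compound 4 is thus estimated at 120 nM, in the range 40 nM to 400 nM.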

Compound 4, half-maximal effective concentration: 208 nM
Compound 4: middle estimate off by 1.7-fold (0.24 log units), on the low side, within the range that was stated.
By their numbers in this assay, from the lowest: compounds 2 and 1 (each within the scatter of the next); then compound 4. At a limit, above all of these: compound 3.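

At this position, on an aromatic carbon para to a large group, 2-(4-methoxyphenyl)ethenyl in place of tert-butyl gives an at least 4.8-fold lower number from compound 3 to compound 4 (0.68 log units; beyond the scatter). The value of compound 3 is a limit of the assay and not a number: the limit of > 1000 nM in this assay, at which 1 of the 4 values shown sits. The ethenyl-carried ring does not match either aryl group, with a 2.2-fold higher number from compound 1 to compound 4 (0.34 log units; beyond the scatter) and a 2.7-fold higher number from compound 2 to compound 4 (0.43 log units; beyond the scatter).

Still open is whether a ring is needed here, as tert-butyl is the only group shown without one. A morpholine, a carboxylic acid or a longer alkyl chain at this position would address that.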